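Unmasking a Diol on the Side Chain

The source may report more compounds than this note shows. Statements on the series, on what has been measured and on what is new or still open speak of the compounds shown alone.

Compound 1 `O=C1c2c[n+]([O-])c3ccccc3c2C(=O)c2c1c1ccccc1n2Cc1cn([C@@H]2C[C@H](O)[C@@H](CO)O2)nn1`: 130 nM
Compound 2 `CC1(C)O[C@@H](CO)[C@H](Cn2cc(Cn3c4c(c5ccccc53)C(=O)c3c[n+]([O-])c5ccccc5c3C4=O)nn2)O1`: 680 nM
Compound 3 `CC1(C)OC[C@@H](Cn2cc(Cn3c4c(c5ccccc53)C(=O)c3c[n+]([O-])c5ccccc5c3C4=O)nn2)O1`: > 1000 nM

Of the compounds shown here, three sharing one core have been tested in a functional assay on MDA-MB-231 cells (Homo sapiens) for cytotoxicity, read by MTT assay, with a stated time of 72 h; a lower number here means a stronger inhibitor, a higher number a weaker inhibitor. Compound 1 gives 130 nM, the lowest number of the set. Compound 2 gives 680 nM, the highest of the two plain numbers. For compound 3 only a limit is reported, > 1000 nM. The step of a 5.2-fold higher number from compound 1 to compound 2 (0.72 log units; beyond the scatter) shows a clear loss, and an at least 1.4-fold higher number from compound 2 to compound 3 (0.16 log units; that floor lies within the scatter) points the same way without leaving the scatter.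

Compound 4 `O=C1c2c[n+]([O-])c3ccccc3c2C(=O)c2c1c1ccccc1n2Cc1cn(C[C@@H](O)CO)nn1` is the next step from compound 2: 1,2-dihydroxyethyl in place of 5-(hydroxymethyl)-2,2-dimethyl-1,3-dioxolan-4-yl on a saturated chain carbon bound to an aromatic nitrogen. The protected ring leaves and a free diol enters, a change running opposite to an at least 1.4-fold higher number from compound 2 to compound 3 (0.16 log units; that floor lies within the scatter), where a hydroxymethyl was removed, and bringing the side chain closer in character to that of compound 1. A modest step downward is therefore expected in this assay. Compound 4 is estimated at 300 nM, in the range from 120 nM to 800 nM, which would be a step of a 2.3-fold lower number from compound 2 to compound 4 (0.36 log units; beyond the scatter).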

Compound 4, half-maximal inhibitory concentration: 670 nM
Beside the measured number, compound 4's estimate is 2.2-fold (0.35 log units) below it, within the range that was stated.
By their numbers in this assay, from the lowest: compound 1; then compounds 4 and 2 (each within the scatter of the next). At a limit, above all of these: compound 3.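

In this assay, replacing the protected ring with a 1,2-dihydroxyethyl on the saturated chain carbon bound to an aromatic nitrogen brings no readable change: a 1.0-fold lower number from compound 2 to compound 4 (0.01 log units; within the scatter). The free diol on an open chain therefore does not close the gap to the oxolane side chain, as a 5.2-fold higher number from compound 1 to compound 4 (0.71 log units; beyond the scatter) shows, so free hydroxyl groups on a 2,3-dihydroxypropyl are not enough to match compound 1. Compound 3 is known only as a limit, so an at least 1.4-fold lower number from compound 3 to compound 4 (0.17 log units; that floor lies within the scatter) gives a floor and no size for that step: the limit of > 1000 nM in this assay, at which 1 of the 4 values shown sits.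

As far as these compounds go, it remains open whether the gain in compound 1 comes from its ring or from the hydroxyl groups on that ring. A bare oxolan-2-yl, or an amine or a carboxylic acid on the open chain, would help separate these possibilities.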